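Halogen Pattern Changes on the Aniline of a Shared Core

This account rests on a few compounds, and the source may have more. Where it says the series, first, only, none or still open, it means among the compounds named here.

Measured compounds:
compound 1 `CN1CCN(CCCOc2cccc3nc(Nc4ccc(Cl)c(F)c4)ccc23)CC1`: 3170 nM
compound 2 `CN1CCN(CCCOc2cccc3nc(Nc4ccc(F)c(F)c4)ccc23)CC1`: 5900 nM
compound 3 `CN1CCN(CCCOc2cccc3nc(Nc4cc(Cl)cc(Cl)c4)ccc23)CC1`: 3190 nM

In a functional assay on cells (Panel colon (Carcinoma cell lines), Homo sapiens) for inhibition, read by sulforhodamine B assay, with a stated time of 48 h (on this read-out higher numbers stand for weaker inhibition of growth and lower numbers for stronger inhibition of growth), compound 3 gives 3190 nM, which lies within the scatter of both compound 1 and compound 2 (a 1.0-fold higher number from compound 1 to compound 3 (0.00 log units; within the scatter); a 1.8-fold lower number from compound 2 to compound 3 (0.27 log units; within the scatter)). Compound 4 `CN1CCN(CCCOc2cccc3nc(Nc4cccc(Cl)c4)ccc23)CC1` differs from compound 3 by hydrogen in place of chloro on an aromatic carbon. Among the compounds with values here, no measured step removes a halogen entirely; the nearest are the halogen rearrangements a 1.9-fold higher number from compound 1 to compound 2 (0.27 log units; within the scatter), a 1.0-fold higher number from compound 1 to compound 3 (0.00 log units; within the scatter) and a 1.8-fold lower number from compound 2 to compound 3 (0.27 log units; within the scatter), each within the scatter. Since every change on this ring among the three measured compounds left this assay unchanged beyond the scatter, no step beyond the scatter is expected for compound 4 in this assay (a 1.3-fold higher number from compound 3 to compound 4 (0.10 log units; within the scatter)). Compound 4 is therefore estimated at 4000 nM, with an expected range of 2000 nM to 9000 nM.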

Compound 4, concentration for total growth inhibition: 3100 nM
Compound 4: middle estimate off by 1.3-fold (0.11 log units), on the high side; the range from low to high includes it.
By their numbers in this assay, from the lowest: compounds 4, 1, 3 and 2 (each within the scatter of the next).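

Within the data shown here, removing one chloro group from the 3,5-dichlorophenyl ring, the first step here that takes a halogen away without replacing it, stays within the scatter in this assay (a 1.0-fold lower number from compound 3 to compound 4 (0.01 log units; within the scatter)). The 3-chlorophenyl group of compound 4 also stays within the scatter of both other anilines (a 1.0-fold lower number from compound 1 to compound 4 (0.01 log units; within the scatter); a 1.9-fold lower number from compound 2 to compound 4 (0.28 log units; within the scatter)), so on this read-out one chloro group is not told apart from these halogen pairs. Nothing measured here offers an explanation for this result.

The compounds shown leave open whether an unsubstituted phenyl ring, or a methoxy group or carboxylic acid in place of the chloro group, would also stay within the scatter.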